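A few compounds are considered here, and "the series" means these few. Any claim that something is new, unique, unknown or untested is made for them only; others in the source may bear on it.

Of the compounds shown here, three sharing one core have been tested in a functional assay on the whole organism (Tail, strain ICR) with Mus musculus as the target, in the tail flick test, with a stated time of 30 min, at a dose of 25 umol/kg by the oral route; a lower number here means a weaker effect, a higher number a stronger effect of the compound at the dose given. Compound 1 `O=C(CN(c1nc(Cl)nc2[nH]cnc12)C1CC1)N[C@@H](CC(=O)OCc1ccccc1)C(=O)OCc1ccccc1` gives 34.7%. Compound 2 `CSCC[C@H](NC(=O)CN(c1ncnc2c1ncn2C1CCCCO1)C1CC1)C(=O)OCc1ccccc1` gives 30%, a value within the scatter of compound 1, while compound 3 `C[C@H](NC(=O)CN(c1ncnc2c1ncn2C1CCCCO1)C1CC1)C(=O)OCc1ccccc1` gives 55.9%, the highest of the three. Compound 1 thus stands second of the three numbers, clearly below compound 3. Among the measured compounds shown here, the only measured step, a number 25.9 percentage points higher from compound 2 to compound 3 (beyond the scatter), concerns a different kind of change and does not bear on compound 4 `NC(=O)C[C@H](NC(=O)CN(c1nc(Cl)nc2[nH]cnc12)C1CC1)C(=O)OCc1ccccc1`, which differs from compound 1 by amino in place of benzyloxy on a carbonyl carbon. For the measured compounds named here, with no step bearing on this change, no shift beyond the scatter is expected, and the expected step is a number 0.3 percentage points higher from compound 1 to compound 4 (within the scatter). Compound 4 is therefore estimated at 35%, with a range from 15% to 55%.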

Compound 4, a percentage reported as activity, at one dose (the size of the read-out at that dose, not a potency): 24.4%
For compound 4 the middle estimate is 10.6 percentage points above the measured one; the measured number falls inside the stated range.
By their numbers in this assay, from the lowest: compounds 4, 2 and 1 (each within the scatter of the next, the first and the last beyond it); then compound 3.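

In this assay the change from benzyloxy to amino on this carbonyl carbon, which turns benzyloxycarbonyl into carbamoyl, gives a number 10.3 percentage points lower from compound 1 to compound 4 (beyond the scatter). This is the first step shown at this position, and it shows that the read-out responds to what sits on this carbonyl carbon, though only modestly. Nothing at hand gives a reason for the loss.

Still open, going by these compounds, is what a methoxy group or a hydroxyl on the same carbonyl carbon would give, the latter making a carboxylic acid. Such groups could show whether the benzene ring of benzyloxy matters or the ester oxygen alone is enough.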